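Methoxy for fluoro on the benzyl ring of compound 3

This account rests on a few compounds, and the source may have more. Where it says the series, first, only, none or still open, it means among the compounds named here.

Compound 3 `Nc1cc(N)c2nc(-c3ccccc3)c(NCc3ccc(F)cc3)nc2c1` carries a 4-fluorophenyl on a saturated chain carbon bound to a nitrogen on an aromatic ring. In a functional assay on Hs-578T cells (Homo sapiens) for inhibition, read by sulforhodamine B assay, with a stated time of 48 h (on this read-out higher numbers stand for weaker inhibition of growth and lower numbers for stronger inhibition of growth), compound 3 gives only a limit, < 100000 nM, and no number. Compound 1 `Nc1cc(N)c2nc(-c3ccccc3)c(NCc3ccc(Cl)c(Cl)c3)nc2c1` bears a 3,4-dichlorophenyl at the same place and gives 46800 nM in this assay. Compound 2 `COc1ccc(CNc2nc3cc(N)cc(N)c3nc2-c2ccccc2)cc1OC` bears a 3,4-dimethoxyphenyl there, and its value in this assay is likewise a limit, < 100000 nM. Compound 4 `COc1ccc(CNc2nc3cc(N)cc(N)c3nc2-c2ccccc2)cc1` differs from compound 3 by methoxy in place of fluoro on an aromatic carbon. The measured steps a step that the limit leaves unreadable from compound 1 to compound 3, a step that the limit leaves unreadable from compound 1 to compound 2 and a step that the two limits leave unreadable from compound 2 to compound 3 all touch this kind of change, yet none of them can be sized because of the limit of < 100000 nM in this assay, at which 2 of the 3 values shown sit. No readable step therefore supports an expectation of a change beyond the scatter, and the single number shown, that of compound 1, sets the scale. Compound 4 is expected to land near 70000 nM, with a range from 25000 nM to 200000 nM. The step expected is a step that the limit leaves unreadable from compound 3 to compound 4.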

Compound 4, concentration for total growth inhibition: < 100000 nM
Compound 4: only a limit was reported; the forecaster's own chance of this, stated with the estimate: 45%; the middle value does not contradict the limit.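

Compound 4 gives only a limit in this assay, so no new step can be read from it to compound 1, compound 2 or compound 3: the limit of < 100000 nM in this assay, at which 3 of the 4 values shown sit.

As far as these compounds go, whether methoxy in place of fluoro changes growth inhibition at all, and in which direction, remains open.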